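1,3-Thiazol-4-yl for 1,2,4-thiadiazol-5-yl on a sulfonamide nitrogen

This account rests on a few compounds, and the source may have more. Where it says the series, first, only, none or still open, it means among the compounds named here.

Compound 1 `COc1cc(C(F)(F)F)ccc1-c1cccc2cc(S(=O)(=O)Nc3ncns3)ccc12` gives 17 10^-6 cm/s
Compound 2 `COc1cc(C(F)(F)F)ccc1-c1cccc2cc(S(=O)(=O)Nc3ccccn3)ccc12` gives 9.5 10^-6 cm/s
Compound 3 `COc1cc(C(F)(F)F)ccc1-c1cccc2cc(S(=O)(=O)Nc3ncccn3)ccc12` gives 36 10^-6 cm/s

In an ADME assay on MDCK cells (Canis lupus familiaris) for permeability (on this read-out higher numbers stand for higher permeability and lower numbers for lower permeability), compound 1 stands among three numbers. Its nearest neighbour is reached by a 1.8-fold lower number from compound 1 to compound 2 (0.25 log units; within the scatter) and its furthest by a 2.1-fold higher number from compound 1 to compound 3 (0.33 log units; beyond the scatter) in this small series.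

The next structure is compound 4 `COc1cc(C(F)(F)F)ccc1-c1cccc2cc(S(=O)(=O)Nc3cscn3)ccc12` and the change is 1,3-thiazol-4-yl in place of 1,2,4-thiadiazol-5-yl on a sulfonamide nitrogen in the core of compound 1, with 1,3-thiazol-4-yl in place of 1,2,4-thiadiazol-5-yl on a sulfonamide nitrogen. The core itself stays the same.

For the measured compounds named here, three measured steps bear on this change, all at the same place. Besides the two above there is a 3.8-fold higher number from compound 2 to compound 3 (0.58 log units; beyond the scatter) in this series. None of them brings in 1,3-thiazol-4-yl, so they show only how far the number has moved when this group was exchanged, from within the scatter to modest.

No step beyond the scatter is therefore expected in this assay and no firm direction can be given. The expectation starts from compound 1 at 17 10^-6 cm/s and its range allows for a move the size of a 2.1-fold higher number from compound 1 to compound 3 (0.33 log units; beyond the scatter) in either direction. The estimated change is a 1.1-fold lower number from compound 1 to compound 4 (0.05 log units; within the scatter) on this reasoning. For compound 4 the expected value is 15 10^-6 cm/s with an estimated range from 7 10^-6 cm/s to 32 10^-6 cm/s in this read-out.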

Compound 4, apparent permeability in the MDCK assay: 27 10^-6 cm/s
Estimate against measurement, compound 4: 1.8-fold (0.26 log units) below; the range from low to high includes it.
By their numbers in the MDCK assay, from the lowest: compounds 2, 1, 4 and 3 (each within the scatter of the next, the first and the last beyond it).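

In the MDCK assay the position takes 1,3-thiazol-4-yl without leaving the span already set by the other rings, with a 1.6-fold higher number from compound 1 to compound 4 (0.20 log units; within the scatter) and a 1.3-fold lower number from compound 3 to compound 4 (0.12 log units; within the scatter). Only the pyridin-2-yl compound stands apart, with a 2.8-fold higher number from compound 2 to compound 4 (0.45 log units; beyond the scatter), so compound 4 cannot be separated from either compound 1 or compound 3, although those two are separated from each other. What the earlier compounds could not show is that this exchange on a sulfonamide nitrogen leaves permeability within the scatter while it makes a large step in a physicochemical assay for acid dissociation, read by capillary electrophoresis, at pH 1.7: the measured acid dissociation constant of compound 1, 3.7, and of compound 4, 7.2, a number 3.50 log units higher (beyond the scatter)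

In the physicochemical assay compound 1 gives 3.7 and compound 4 gives 7.2. For this one pair, then, a large move in acid dissociation does not come with a step beyond the scatter in permeability, but a single pair cannot tell whether that holds for the pyridin-2-yl and pyrimidin-2-yl compounds as well. As far as these compounds go, it also remains open whether a group of another kind on the sulfonamide nitrogen, such as a simple methyl or a 1,3-oxazol-4-yl ring, would stay within the same span in the MDCK assay.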